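Removing a methoxy from the indole core: what to expect

The source may hold more compounds than are shown below. What is called first, only, known or untested is meant among the compounds shown, and "the series" means these compounds.

Measured compounds:
- Compound 1, `N#C/C(=C\c1c(-c2ccccc2)[nH]c2ccccc12)C(=O)c1cccs1`: 600 nM
- Compound 2, `CCOC(=O)/C(=C/c1c(-c2ccccc2)[nH]c2ccccc12)C(=O)c1ccc([N+](=O)[O-])cc1`: 2200 nM
- Compound 3, `COc1ccc(-c2[nH]c3ccc(OC)cc3c2/C=C(\C#N)S(=O)(=O)c2ccccc2)cc1`: 300 nM

All three compounds were tested in a functional assay on CCRF-SB cells (Homo sapiens) for cytotoxicity, read by MTT assay, with a stated time of 96 h (on this read-out higher numbers stand for an effect only at larger amounts of compound and lower numbers for an effect already at smaller amounts), which records the concentration of compound needed to reduce the viability of the cells by half. Compound 3 shows the lowest number of the three, 300 nM. Its gap to compound 1, at 600 nM, lies within the usual scatter of repeated measurements, so the two cannot be ranked against each other on these data. Its gap to compound 2, at 2200 nM, is wider and lies beyond the scatter.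

Compound 4, `COc1ccc(-c2[nH]c3ccccc3c2/C=C(\C#N)S(=O)(=O)c2ccccc2)cc1`, has not yet been measured in this assay. It differs from compound 3 in one place: hydrogen in place of methoxy on an aromatic carbon. The rest of the molecule is unchanged.

Within the data shown here, no pair of measured compounds differs in just this way, so there is no measured step to lean on. A small change of this kind, a single methoxy gone from the fused ring, is expected to shift the number little; the step of a 1.5-fold higher number from compound 3 to compound 4 (0.18 log units; within the scatter) is estimated to stay within the scatter, with a slight lean toward a higher number. Compound 4 is therefore expected to give about 450 nM, most likely between 150 nM and 1300 nM.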

Compound 4, half-maximal effective concentration: 300 nM
Estimate against measurement, compound 4: 1.5-fold (0.18 log units) above, and the stated range covers the measured number.
By their numbers in this assay, from the lowest: compounds 3, 4 and 1 (each within the scatter of the next); then compound 2.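

Among these compounds, replacing the methoxy with hydrogen on the fused part of the molecule gives no change at the digits printed from compound 3 to compound 4 (within the scatter) in this assay, and this is the first direct comparison in this set in which only one place differs. At this position, the methoxy is therefore not needed to keep the number at this level on these cells, and its carbon and oxygen can leave without a detectable shift in this read-out. Among the compounds shown here, this shows only that the two compounds give the same number, and no measurement here offers an explanation for that.

On these data alone, a single swap between two small substituents says little about what else this position would accept, so it remains open whether an amine, a carboxylic acid or a longer chain such as butoxy would leave the number just as unmoved. Also open, as far as these compounds go, is whether the methoxy that compound 4 still carries elsewhere in the molecule could be replaced by hydrogen with the same result.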